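The compounds below may be only part of what the source reports. "The series", "measured", "known", "first", "only" and "open" are said of these compounds alone.

Compound 1 `CC1CCN(C2CCN(S(=O)(=O)c3cccc(C(F)(F)F)c3)CC2)CC1` gives > 5000 nM in an ADME assay on HCT-116 cells (Homo sapiens) for cytotoxicity, read by CellTiter-Glo, with a stated time of 72 h; a higher number here means a weaker inhibitor, a lower number a stronger inhibitor
Compound 2 `CC1CCN(C2CCN(S(=O)(=O)c3cccnc3Cl)CC2)CC1` gives > 10000 nM in this assay

Compound 2 stands at the limit of > 10000 nM in this assay, at which 1 of the 2 values shown sits, and so reads only as a limit, not as a number. Compound 1, with > 5000 nM as its reading, is a limit too. Compound 3 `CC1CCN(C2CCN(S(=O)(=O)c3ccccc3Br)CC2)CC1` changes compound 2 in one place, with 2-bromophenyl in place of 2-chloropyridin-3-yl on a sulfonyl sulfur. Among the compounds with values here, no measured pair shows what such a change does in this assay. No shift beyond the scatter is expected here, in either direction, and the expected step (a number no higher from compound 2 to compound 3 (the limit leaves the size open)) is estimated on that basis. This expectation rests on compound 2 with its limit of > 10000 nM as the only anchor. For compound 3 the estimated value is 10000 nM with an expected range from 3000 nM to 30000 nM in this measurement.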

Compound 3, half-maximal inhibitory concentration: > 5000 nM
Compound 3: a limit, no number (the forecaster's own chance of this, stated with the estimate: 75%); the middle value does not contradict the limit.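

Compound 2 and compound 3 both read only as limits in this assay, and no step can be read between them. The compounds shown leave open whether 2-bromophenyl in place of 2-chloropyridin-3-yl on a sulfonyl sulfur shifts the half-maximal inhibitory concentration at all, and in which direction.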